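From an Amide to an Amine on the Pyrrolidine Ring

The source may report more compounds than this note shows. Statements on the series, on what has been measured and on what is new or still open speak of the compounds shown alone.

Of the compounds shown here, two share a core and have been measured so far. Compound 1 `CC(C)(C)OC(=O)N1C(=O)CC[C@H]1C(=O)N1CCC(NS(=O)(=O)c2cc(S(=O)(=O)c3ccccc3)ccc2C(F)(F)F)CC1` carries a tert-butoxycarbonyl group on its five-membered ring, and in a physicochemical assay for solubility (a higher number here means a more soluble compound, a lower number a less soluble compound), compound 1 gives 50000 nM. Compound 2 `CC(C)(C)C(=O)N1CCC[C@H]1C(=O)N1CCC(NS(=O)(=O)c2cc(S(=O)(=O)c3ccccc3)ccc2C(F)(F)F)CC1` carries a (tert-butyl)carbonyl group instead, and in this assay compound 2 gives 50000 nM. Compound 2 therefore stands level with compound 1 at the digits shown, the two values sitting within the scatter of each other, so no order between them can be read.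

Compound 3 `CC(C)(C)CCN1CCC[C@H]1C(=O)N1CCC(NS(=O)(=O)c2cc(S(=O)(=O)c3ccccc3)ccc2C(F)(F)F)CC1` has not yet been measured. It differs from compound 2 in one place: 3,3-dimethylbutyl in place of (tert-butyl)carbonyl on an amine nitrogen in a ring. For the measured compounds named here, no step between measured compounds covers this kind of change, so there is no direct precedent in the data. The expectation is a small upward step, or none beyond the scatter, from compound 2 to compound 3, expressed as a 1.4-fold higher number from compound 2 to compound 3 (0.15 log units; within the scatter). Compound 3 is estimated to give 70000 nM in this assay, with a range from 25000 nM to 200000 nM.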

Compound 3, solubility: 12500 nM
Estimate against measurement, compound 3: 5.6-fold (0.75 log units) above, and the stated range ends above it.
By their numbers in this assay, from the lowest: compound 3; then compounds 1 and 2 (each within the scatter of the next).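

Replacing (tert-butyl)carbonyl with 3,3-dimethylbutyl on the amine nitrogen in the ring gives a 4.0-fold lower number from compound 2 to compound 3 (0.60 log units; beyond the scatter) in this assay and is beyond the scatter, so the number at this position does respond to the group attached there. For the compounds shown here, compounds 1 and 2 offered no one-place step, which makes this the first change that can be read cleanly. The heavy-atom count stays the same, while the carbonyl oxygen, the double bond and the hydrogen-bond acceptor all leave, so the count alone does not separate these two groups. Nothing measured here explains why the number falls.

This single step cannot show whether the carbonyl's departure or the arrival of the 3,3-dimethylbutyl chain matters more. A shorter chain such as ethyl, a chain ending in a carboxylic acid, or a plain hydrogen on this nitrogen would help pull those two parts apart and show how far the result extends beyond this one pair.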